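The source may hold more compounds than are shown below. What is called first, only, known or untested is meant among the compounds shown, and "the series" means these compounds.

Compound 1 `O=C(O)c1cc(-c2cccc(COc3ccc4c(c3)CN(C3CCCC3)C4=O)c2)ccc1O`: 20 nM
Compound 2 `O=C1c2ccc(OCc3cccc(-c4ccc(C(F)(F)F)cc4F)c3)cc2CN1C1CCCC1`: > 5000 nM

In an assay on HEK293 cells for positive allosteric modulation of metabotropic glutamate receptor 2 (Rattus norvegicus), read by thallium flux (on this read-out lower numbers stand for an effect already at smaller amounts and higher numbers for an effect only at larger amounts of compound), compound 2 gives only a limit, > 5000 nM, not a number (the limit of > 5000 nM in this assay, at which 1 of the 2 values shown sits). Compound 3 `O=C(O)c1ccc(Cl)c(-c2cccc(COc3ccc4c(c3)CN(C3CCCC3)C4=O)c2)c1` differs from compound 2 by 5-carboxy-2-chlorophenyl in place of 2-fluoro-4-(trifluoromethyl)phenyl on an aromatic carbon. Among the measured compounds shown here, the one measured step, an at least 250-fold higher number from compound 1 to compound 2 (2.39 log units; beyond the scatter), removed a carboxy-bearing ring and cost a large amount; the change to compound 3 puts a carboxy-bearing ring back, though with chloro rather than hydroxy. A large gain is therefore expected, the estimated step being an at least 33-fold lower number from compound 2 to compound 3 (1.52 log units; beyond the scatter). Compound 3 is expected to give 150 nM, likely between 25 nM and 1500 nM.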

Compound 3, half-maximal effective concentration: 90 nM
The estimate for compound 3 lay 1.7-fold (0.22 log units) above the measured number; the range from low to high includes it.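

In this assay, 5-carboxy-2-chlorophenyl at this position brings an at least 55-fold lower number from compound 2 to compound 3 (1.74 log units; beyond the scatter), so a carboxy-bearing ring with chloro instead of hydroxy also gives a measurable effect. Among the compounds shown here, that step starts from a limit, not a number, the one for compound 2: the limit of > 5000 nM in this assay, at which 1 of the 3 values shown sits. The two carboxy-bearing rings are not interchangeable, since 5-carboxy-2-chlorophenyl in place of 3-carboxy-4-hydroxyphenyl gives a 4.5-fold higher number from compound 1 to compound 3 (0.65 log units; beyond the scatter), a modest cost.

The compounds shown leave open whether a tetrazole or a primary amide could stand in for the carboxylic acid. They also leave open what the chloro or the hydroxy contributes on its own.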